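From compound 2 to compound 3: one aryl group exchanged

The source may report more compounds than this note shows. Statements on the series, on what has been measured and on what is new or still open speak of the compounds shown alone.

Compound 1 `COc1ccccc1/C=C1\CCC/C(=C\c2cccc(OC)c2OC)C1=O` gives only a limit in a functional assay on SW-620 cells (Homo sapiens) for cytotoxicity, read by MTT assay, with a stated time of 72 h (a lower number here means a stronger inhibitor, a higher number a weaker inhibitor), namely > 20000 nM. Going by the values given here, compound 2 `COc1ccc(/C=C2\CCC/C(=C\c3cccc(OC)c3OC)C2=O)cc1` gives the only actual number in this assay, 13600 nM. The standing of compound 2 can be read only against the limit of compound 1. Among the compounds with values here, the one measured step is an at least 1.4-fold lower number from compound 1 to compound 2 (0.16 log units; that floor lies within the scatter), with 4-methoxyphenyl in place of 2-methoxyphenyl on a double-bonded chain carbon bound to a double-bonded ring carbon. This step has a floor and no exact size, and the ceiling of the data is the limit of > 20000 nM in this assay, at which 1 of the 2 values shown sits.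

Compound 3 `COc1cccc(/C=C2\CCC/C(=C\c3cccc(O)c3)C2=O)c1OC` changes the same group again: 3-hydroxyphenyl in place of 4-methoxyphenyl on a double-bonded chain carbon bound to a double-bonded ring carbon. Here 3-hydroxyphenyl replaces 4-methoxyphenyl, while the rest of the structure stays as in compound 2. Within the data shown here, no measured step covers a hydroxyl group, so the only guide is an at least 1.4-fold lower number from compound 1 to compound 2 (0.16 log units; that floor lies within the scatter), which stays within the scatter. A step beyond the scatter is therefore not expected, in either direction. The expected step is a 1.1-fold lower number from compound 2 to compound 3 (0.05 log units; within the scatter). A result reported only as a limit is also plausible. For compound 3 the estimated value is 12000 nM, with an expected range of 5000 nM to 20000 nM.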

Compound 3, half-maximal inhibitory concentration: 6400 nM
The estimate for compound 3 lay 1.9-fold (0.27 log units) above the measured number; the measured number falls inside the stated range.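

At this place, on a double-bonded chain carbon bound to a double-bonded ring carbon, the aryl exchange now gives a step of exact size in this assay that clears the scatter (a 2.1-fold lower number from compound 2 to compound 3 (0.33 log units; beyond the scatter)). Measured against 2-methoxyphenyl, the same 3-hydroxyphenyl group gives a larger reading (an at least 3.1-fold lower number from compound 1 to compound 3 (0.49 log units; beyond the scatter)), but that step has only a floor and no exact size: the limit of > 20000 nM in this assay, at which 1 of the 3 values shown sits. With both of its steps beyond the scatter, compound 3 has the lowest number of the three, and it is also the only one of them whose changing aryl group carries a hydrogen-bond donor, a link that rests on this single compound.

The exchange from compound 2 to compound 3 alters both the group and where it sits on the phenyl ring, so 3-methoxyphenyl and 4-hydroxyphenyl in this place would be needed to tell the hydroxyl group from its placement. From the compounds shown here alone, how an aminophenyl or a carboxyphenyl group would read here, and whether the other aryl group, kept constant in all three compounds, tolerates any such exchange, also stays open.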